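The source may report more compounds than this note shows. Statements on the series, on what has been measured and on what is new or still open speak of the compounds shown alone.

Measured so far in a functional assay on HeLa cells (Homo sapiens) for inhibition, read by CCK-8 assay, with a stated time of 72 h, tested at 8 uM; on this read-out lower numbers stand for less inhibition of growth and higher numbers for more inhibition of growth at the one concentration tested

Compound 1 `CCc1ccc(SCc2ccc(/C=C/C(=O)Nc3ccccc3N)cc2)cc1` gives 20.9%
Compound 2 `Nc1ccccc1NC(=O)c1ccc(CSc2cccc(F)c2)cc1` gives 78.4%
Compound 3 `Nc1ccccc1NC(=O)c1ccc(CSc2nccc(C(F)(F)F)n2)cc1` gives 83.4%

Compound 2 at 78.4% and compound 3 at 83.4% are level within the usual scatter. Compound 1 at 20.9% stands lower than compound 2, beyond that scatter, but the two differ in more than one place, so this gap says little about any single group.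

The next molecule, compound 4 `Nc1ccccc1NC(=O)c1ccc(CSCCc2ccccc2)cc1`, has phenethyl in place of 3-fluorophenyl on a sulfur . For the measured compounds named here, no measured pair of compounds isolates this change, so any forecast is uncertain. Compound 3 carries another group on its sulfur and gives 83.4% in this test, so a large loss is not expected. The estimated a number 6.4 percentage points lower from compound 2 to compound 4 (within the scatter) in this assay is a small fall, and no step beyond the scatter is expected. For compound 4 the estimated value is 72% with an expected range from 50% to 88% as the likely span.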

Compound 4, percent growth inhibition at one concentration: 74.8%
Estimate against measurement, compound 4: 2.8 percentage points below; the measured number falls inside the stated range.
By their numbers in this assay, from the lowest: compound 1; then compounds 4, 2 and 3 (each within the scatter of the next).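

In this assay, the step from 3-fluorophenyl to phenethyl on the sulfur reads a number 3.6 percentage points lower from compound 2 to compound 4 (within the scatter), and this is the first pair shown that differs in one place only. This group on the sulfur can therefore lose its fluorine and gain a saturated chain in front of its ring, with no shift beyond the usual scatter at the one concentration tested. No supporting measurement bears on this result.

The two alterations arrive together, so the compounds shown cannot separate the effect of the fluorine from that of the chain, which a plain phenyl on the sulfur could help to do. Also open, going by these compounds, is whether a longer chain carrying an amine or a carboxylic acid would keep growth inhibition at this level.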